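Sulfonate ester ureas: a larger ring on the urea nitrogen

This account rests on a few compounds, and the source may have more. Where it says the series, first, only, none or still open, it means among the compounds named here.

The three measured compounds share one core and differ only at the carbonyl substituent. Compound 1 `O=C(CCCl)Nc1ccc(S(=O)(=O)Oc2ccccc2I)cc1` gives 12000 nM in a functional assay on M21 cells (Homo sapiens) for antiproliferative activity, read by sulforhodamine B assay, with a stated time of 48 h (a lower number here means a stronger inhibitor, a higher number a weaker inhibitor), compound 2 `CCCNC(=O)Nc1ccc(S(=O)(=O)Oc2ccccc2I)cc1` gives 5400 nM, and compound 3 `O=C(Nc1ccc(S(=O)(=O)Oc2ccccc2I)cc1)NC1CC1` gives 11000 nM. Compound 3 therefore stands second highest of the three; against compound 1 it lies within the scatter, while a 2.0-fold higher number from compound 2 to compound 3 (0.31 log units; beyond the scatter) is a modest step beyond it. Compound 4 `O=C(NCC1CCCC1)Nc1ccc(S(=O)(=O)Oc2ccccc2I)cc1` differs from compound 3 by cyclopentylmethyl in place of cyclopropyl on an amide-type nitrogen. Among the measured compounds shown here, the only step bearing on this change is a 2.0-fold higher number from compound 2 to compound 3 (0.31 log units; beyond the scatter), where an open chain in place of the small ring gave the lower number. A similar, modest improvement is therefore expected for compound 4, a 1.8-fold lower number from compound 3 to compound 4 (0.26 log units; within the scatter). Compound 4 is estimated at 6000 nM, with a range of 2500 nM to 15000 nM.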

Compound 4, half-maximal inhibitory concentration: 7600 nM
For compound 4 the middle estimate is 1.3-fold (0.10 log units) below the measured one, within the range that was stated.
By their numbers in this assay, from the lowest: compounds 2, 4, 3 and 1 (each within the scatter of the next, the first and the last beyond it).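

In this assay the larger ring on the amide-type nitrogen changed little, with a 1.4-fold lower number from compound 3 to compound 4 (0.16 log units; within the scatter) for cyclopentylmethyl in place of cyclopropyl. Compound 4 also cannot be separated from the other two, with a 1.4-fold higher number from compound 2 to compound 4 (0.15 log units; within the scatter) and a 1.6-fold lower number from compound 1 to compound 4 (0.20 log units; within the scatter) both read alongside that step, so cyclopentylmethyl sits among all three earlier groups at this position. Nothing measured here offers an explanation for this result. The compounds shown leave open how a longer chain such as hexyl would compare on this nitrogen. They also leave open the effect of an amine or a carboxylic acid carried on that chain.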